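This account rests on a few compounds, and the source may have more. Where it says the series, first, only, none or still open, it means among the compounds named here.

Within the data shown here, in a physicochemical assay for solubility, read by LC-MS, in phosphate buffer, with a stated time of 24 h, at pH 7.4 (a lower number here means a less soluble compound, a higher number a more soluble compound), compound 3 (`CN(c1ncco1)c1cnc(NCc2c(F)ccc3c2CCO3)n2cnnc12`) gives 67000 nM, the highest number among the compounds measured so far, and compound 2 (`Cn1cc(-c2cnc(NCc3c(F)ccc4c3CCO4)c3cn[nH]c(=O)c23)cn1`) gives 1000 nM. Compound 1 (`O=C(Nc1ccccc1)c1cnc(NCc2c(F)ccc3c2CCO3)n2cnnc12`) is reported only as a limit, < 1000 nM.

Compound 4 (`Fc1ccc2c(c1CNc1ncc(Oc3ccccc3)c3nncn13)CCO2`) keeps the rest of compound 3 but carries phenoxy in place of methyl(1,3-oxazol-2-yl)amino on an aromatic carbon. The incoming group brings a six-membered aromatic ring of carbon only.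

A single measured step bears on this change, an at least 67-fold higher number from compound 1 to compound 3 (1.82 log units; beyond the scatter). On these data alone, it is large and beyond the scatter, and it rests on (the limit of < 1000 nM in this assay, at which 1 of the 3 values shown sits), so its full size stays open. In that step, the methyl(1,3-oxazol-2-yl)amino group replaces phenylcarbamoyl, which also contains a ring of carbon only. Read in reverse, it suggests that losing the group may bring the number down a long way. However, phenoxy and phenylcarbamoyl are different groups, and this is only one comparison, so the size of the drop is uncertain.

A large step to a lower number is therefore expected, and the estimated change is a 17-fold lower number from compound 3 to compound 4 (1.22 log units; beyond the scatter). For compound 4 the expected value is 4000 nM, with an estimated range from 700 nM to 25000 nM.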

Compound 4, solubility: 8000 nM
Estimate against measurement, compound 4: 2.0-fold (0.30 log units) below; measured number inside the range.
By their numbers in this assay, from the lowest: compound 2; then compound 4; then compound 3.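

At this position, a group with a six-membered aromatic ring of carbon only gives up part of the number reached with the five-membered aromatic ring with 2 hetero atoms in this assay: the change is an 8.4-fold lower number from compound 3 to compound 4 (0.92 log units; beyond the scatter), which is modest in size. A ring of carbon only does not, however, tie the number to the low end, as phenoxy and phenylcarbamoyl both contain one and the comparison between them gives an at least 8.0-fold higher number from compound 1 to compound 4 (0.90 log units; beyond the scatter). Compound 1 is reported only as a limit, so this second step has a known minimum and no known full size: the limit of < 1000 nM in this assay, at which 1 of the 4 values shown sits.

The compounds shown cannot separate the parts of methyl(1,3-oxazol-2-yl)amino, so it stays open whether the high number of compound 3 goes with the ring, the methyl group or the linking nitrogen. A small amine or a carboxylic acid at this same aromatic carbon would show how the number behaves when the incoming group has no aromatic ring at all.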